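The source may report more compounds than this note shows. Statements on the series, on what has been measured and on what is new or still open speak of the compounds shown alone.

Compound 3 `Oc1ccc(-c2cn(C3CN4CCC3CC4)nn2)cc1` gives 3.44 nM in an assay on HEK293 cells for displacement of a labelled ligand from Neuronal acetylcholine receptor; alpha3/beta4 (Homo sapiens), read by scintillation counting, with a stated time of 120 min (a lower number here means a stronger inhibitor, a higher number a weaker inhibitor), the second highest of the three numbers shown. Compound 1 `Fc1ccc(-c2cn(C3CN4CCC3CC4)nn2)cc1` gives 8.5 nM, and compound 2 `Oc1ccc(-c2cn([C@@H]3CN4CCC3CC4)nn2)cc1` gives 2.48 nM. The step of a 2.5-fold lower number from compound 1 to compound 3 (0.39 log units; beyond the scatter) is modest, while the step of a 1.4-fold higher number from compound 2 to compound 3 (0.14 log units; within the scatter) stays within the scatter, a pair that differs only because of the fact that one of compounds 2 and 3 is drawn with a defined configuration and the other without, at the place where they differ. Compound 4 `Oc1ccc(-c2cn([C@H]3CN4CCC3CC4)nn2)cc1` differs from compound 3 in that (the two compounds have the same atoms and bonds; at least one stereo element is drawn with a configuration in one of them and without one in the other: 1 of 3 stereo elements differ; a stereocentre at a saturated ring carbon is drawn without a configuration in compound 3 and R in compound 4). Since compound 3 is drawn without a configuration at that centre and compound 2 carries the opposite configuration, the step of a 1.6-fold higher number from compound 3 to compound 4 (0.20 log units; within the scatter) is expected to be small and, if anything, upward. Compound 4 is therefore estimated at 5.5 nM in this assay, within a range from 2 nM to 15 nM.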

Compound 4, inhibition constant: 138 nM
The estimate for compound 4 lay 25-fold (1.40 log units) below the measured number; the measured number lies above the stated range.
By their numbers in this assay, from the lowest: compounds 2 and 3 (each within the scatter of the next); then compound 1; then compound 4.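

In this assay the configuration at the saturated ring carbon turns out to matter greatly, with R far weaker than S, as the step of a 56-fold higher number from compound 2 to compound 4 (1.75 log units; beyond the scatter) shows. The step of a 40-fold higher number from compound 3 to compound 4 (1.60 log units; beyond the scatter) is also large, so compound 3, drawn without a configuration, stands close to compound 2 and well apart from compound 4. This second step rests on one difference alone: the fact that one of compounds 3 and 4 is drawn with a defined configuration and the other without, at the place where they differ

Going by these compounds, what compound 3 actually contains at that centre remains unknown. On these data alone, it also remains open whether the R configuration weakens binding as much when a methoxy group or an amine replaces the hydroxy.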